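Notes on the amide tail of the shared core

This account rests on a few compounds, and the source may have more. Where it says the series, first, only, none or still open, it means among the compounds named here.

Measured compounds:
compound 1 `Cn1c(-c2ccc(NC(=O)CSc3nc4cc(Cl)ccc4o3)cc2)nc(-c2ccccc2)c1-c1ccccc1`, 79.6%
compound 2 `Cc1ccc2oc(SCC(=O)Nc3ccc(-c4nc(-c5ccccc5)c(-c5ccccc5)n4C)cc3)nc2c1`, 69.8%
compound 3 `Cn1c(-c2ccc(NC(=O)CSc3nc4ccccc4s3)cc2)nc(-c2ccccc2)c1-c1ccccc1`, 82.7%

In a functional assay on HT-29 cells (Homo sapiens) for cytotoxicity, read by MTT assay, with a stated time of 24 h, tested at 80 ug/mL (a lower number here means a weaker effect, a higher number a stronger effect of the compound at the concentration tested), compound 1 stands second highest of the three numbers. Its nearest neighbour is compound 3, a number 3.1 percentage points higher from compound 1 to compound 3 (within the scatter); the furthest is compound 2, a number 9.8 percentage points lower from compound 1 to compound 2 (within the scatter). For the measured compounds named here, both of these steps stay within the scatter, and only the pair of compounds 2 and 3 shows a step beyond it, a number 12.9 percentage points higher from compound 2 to compound 3 (beyond the scatter), which is still modest.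

Compound 4 `CCN1CCN(CC(=O)Nc2ccc(-c3nc(-c4ccccc4)c(-c4ccccc4)n3C)cc2)CC1` is not yet measured. It differs from compound 1 as follows: 4-ethylpiperazin-1-yl in place of (5-chloro-1,3-benzoxazol-2-yl)sulfanyl on a saturated chain carbon bound to a carbonyl carbon.

Going by the values given here, none of the measured steps covers a change of this kind. All three swap one benzazole for another on the same sulfur, or change a substituent on that ring, and none removes the sulfanyl-linked aromatic group. Among the compounds with values here, the measured steps therefore show only that small changes in that region leave this assay nearly unchanged; they give no guide to a replacement by 4-ethylpiperazin-1-yl. The expectation for compound 4 in this assay is a step downward beyond the scatter, with wide uncertainty, a number 24.6 percentage points lower from compound 1 to compound 4 (beyond the scatter). Compound 4 is estimated at 55%, in the range 25% to 82%.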

Compound 4, a percentage reported as activity, at one concentration (the size of the read-out at that concentration, not a potency): 51.2%
Compound 4: the middle estimate sits 3.8 percentage points above what was measured, within the range that was stated.
By their numbers in this assay, from the lowest: compound 4; then compounds 2, 1 and 3 (each within the scatter of the next, the first and the last beyond it).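

In this assay, 4-ethylpiperazin-1-yl on the saturated chain carbon bound to a carbonyl carbon gives the first clear separation from all the aromatic sulfanyl groups, with a number 28.4 percentage points lower from compound 1 to compound 4 (beyond the scatter) and a number 18.6 percentage points lower from compound 2 to compound 4 (beyond the scatter) and also a number 31.5 percentage points lower from compound 3 to compound 4 (beyond the scatter) as the three steps. All three run in the same direction and lie beyond the scatter, so this position does respond to a change of the whole group, whereas the exchanges among the aromatic groups on sulfur had moved the read-out beyond the scatter only once, in a number 12.9 percentage points higher from compound 2 to compound 3 (beyond the scatter) on that pair. The read-out is reduced rather than abolished, since compound 4 still gives 51.2% at the single concentration tested, and nothing shown here bears on why the change lowers it.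

As far as these compounds go, the change removes the sulfur and both aromatic rings and brings in the piperazine all at once, so which of these parts carries the fall stays open. A phenylsulfanyl group, a morpholin-4-yl group or a 4-phenylpiperazin-1-yl group on the same carbon would begin to separate these parts.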